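A few compounds are considered here, and "the series" means these few. Any claim that something is new, unique, unknown or untested is made for them only; others in the source may bear on it.

Compound 2 `Cc1ccccc1C(=O)Nc1ccc(S(=O)(=O)NC2CCN(C(=O)CO)CC2)c2ccccc12` gives 5.4 nM in an assay on L1.2 cells for binding affinity to C-C chemokine receptor type 8 (Homo sapiens) (a lower number here means a stronger inhibitor, a higher number a weaker inhibitor), the lowest of the two single numbers in this set; compound 1 `Cc1ccccc1C(=O)Nc1ccc(S(=O)(=O)NC2CCN(C(=O)C3CCCC3)CC2)c2ccccc12` gives 9.1 nM, and the step of a 1.7-fold lower number from compound 1 to compound 2 (0.23 log units; within the scatter) lies within the scatter. Compound 3 `Cc1ccccc1C(=O)Nc1ccc(S(=O)(=O)NC2CCN(C(=O)[C@@H]3CCCN3)CC2)c2ccccc12` gives 0.7 nM; 1 nM (2 entries) (the several entries of compound 3 in this assay, 0.7 nM; 1 nM (2 entries)), without a single number to compare. Compound 4 `CCCC(=O)N1CCC(NS(=O)(=O)c2ccc(NC(=O)c3ccccc3C)c3ccccc23)C1` differs from compound 2 in one place: 1-(propylcarbonyl)pyrrolidin-3-yl in place of 1-((hydroxymethyl)carbonyl)piperidin-4-yl on a sulfonamide nitrogen. Among the compounds with values here, only the step from compound 1 to compound 2 bears on it, and that step touched the acyl group alone and stayed within the scatter; the change from the six-membered to the five-membered ring, with the move of the attachment point, has no measured counterpart here. The expected outcome for compound 4 in this assay is therefore a modest rise in number, a 2.8-fold higher number from compound 2 to compound 4 (0.44 log units; beyond the scatter), with wide uncertainty. Compound 4 is estimated at 15 nM, within a range from 4 nM to 60 nM.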

Compound 4, inhibition constant: 34.3 nM
Compound 4: middle estimate off by 2.3-fold (0.36 log units), on the low side; low and high end bracket the measured number.
By their numbers in this assay, from the lowest: compounds 2 and 1 (each within the scatter of the next); then compound 4.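

The exchange of 1-((hydroxymethyl)carbonyl)piperidin-4-yl for 1-(propylcarbonyl)pyrrolidin-3-yl on a sulfonamide nitrogen gives a change beyond the scatter in this assay, with a 6.4-fold higher number from compound 2 to compound 4 (0.80 log units; beyond the scatter). The earlier step, a 1.7-fold lower number from compound 1 to compound 2 (0.23 log units; within the scatter), touched only the acyl group and stayed within the scatter, so the number at this position does respond to at least this combined exchange of ring and acyl group. No measurement given here bears on why the number rose.

Still open, going by these compounds, is how much of the step belongs to the ring and how much to the acyl group, which a 1-(propylcarbonyl)piperidin-4-yl group on the same nitrogen would help to separate. Also open, on these data alone, is how the five-membered ring would read with a carboxylic acid or a longer chain on its carbonyl.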